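Same atoms, different stereocentres: from compound 3 to compound 4

This account rests on a few compounds, and the source may have more. Where it says the series, first, only, none or still open, it means among the compounds named here.

Measured so far in a functional assay on the whole organism with Mus musculus as the target, in the writhing test; on this read-out higher numbers stand for an effect only at larger amounts of compound and lower numbers for an effect already at smaller amounts:
- compound 1 `CCCCSc1nsnc1C1CN2CCCC1C2`: 0.03 mg/kg
- compound 2 `FC(F)(F)CCCCSc1nsnc1[C@@H]1CN2CCC[C@@H]1C2`: 0.07 mg/kg
- compound 3 `FC(F)(F)CCCSc1nsnc1[C@H]1CN2CCC[C@H]1C2`: 0.1 mg/kg

In this assay, compound 3 gives 0.1 mg/kg. This is the highest number of the three, but that ranking holds only against compound 1, where the gap is beyond the usual scatter. Compound 3 and compound 2 lie within the scatter of each other, so they cannot be told apart.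

The next compound is compound 4 `FC(F)(F)CCCSc1nsnc1[C@@H]1CN2CCC[C@@H]1C2`. It has the same atoms and bonds as compound 3, and only the drawn arrangement in space changes: the two compounds have the same atoms and bonds; at least one stereo element is drawn with a configuration in one of them and without one in the other: 2 of 3 stereo elements differ; a stereocentre at a saturated ring carbon is drawn R in compound 3 and S in compound 4; a stereocentre at a saturated ring carbon is drawn R in compound 3 and S in compound 4. Stereocentres can matter in a living system, yet no measured pair here shows what this kind of change does. Among the measured compounds shown here, the only guide is the modest spread of the measured values, from compound 1 at 0.03 mg/kg to compound 3 at 0.1 mg/kg. The expected 1.3-fold lower number from compound 3 to compound 4 (0.10 log units; within the scatter) is therefore none beyond the scatter, with real uncertainty in either direction. Compound 4 is estimated at 0.08 mg/kg, with an expected range from 0.02 mg/kg to 0.4 mg/kg.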

Compound 4, dose for half-maximal effect: 0.35 mg/kg
Compound 4: middle estimate off by 4.4-fold (0.64 log units), on the low side; the range from low to high includes it.
By their numbers in this assay, from the lowest: compound 1; then compounds 2 and 3 (each within the scatter of the next); then compound 4.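

In this assay, the drawn arrangement at the two saturated ring carbons matters on its own: with atoms and bonds unchanged, the result is a 3.5-fold higher number from compound 3 to compound 4 (0.54 log units; beyond the scatter). The side chain also matters when the configuration at those ring carbons stays as drawn, with trifluoromethyl in place of 2,2,2-trifluoroethyl giving a 5.0-fold higher number from compound 2 to compound 4 (0.70 log units; beyond the scatter). One caution applies to the first of these steps, which may not reflect the two ring carbons alone: the fact that one of compounds 3 and 4 is drawn with a defined configuration and the other without, at the place where they differ.

The compounds shown leave open whether the same change of arrangement would have a similar effect with the longer chain of compound 2 or the fluorine-free chain of compound 1. They also leave open how a chain carrying an amine or a carboxylic acid in place of the fluorines would behave.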